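Chloro to fluoro at the phenoxy end of a weak series

A few compounds are considered here, and "the series" means these few. Any claim that something is new, unique, unknown or untested is made for them only; others in the source may bear on it.

Measured compounds:
compound 1, `CCN(CC)CCCC(C)Nc1ccnc(COc2ccccc2Cl)c1`, 17000 nM
compound 2, `CCN(CC)CCCC(C)Nc1ccnc(COc2ccc(Cl)cc2)c1`, 20000 nM

For the measured compounds named here, in an assay on isolated protein for inhibition of C-C chemokine receptor type 4 (Homo sapiens) (on this read-out higher numbers stand for weaker inhibition and lower numbers for stronger inhibition), compound 2 gives 20000 nM, the higher of the two numbers so far; the nearest is compound 1 with 17000 nM, and the step of a 1.2-fold higher number from compound 1 to compound 2 (0.07 log units; within the scatter) lies within the scatter, so the two cannot be ordered. Compound 3, `CCN(CC)CCCC(C)Nc1ccnc(COc2ccc(F)cc2)c1`, differs from compound 2 by fluoro in place of chloro on an aromatic carbon. Going by the values given here, no measured step swaps one halogen for another; the only step in hand, from compound 1 to compound 2, moves the chloro group to another site and was within the scatter, so the data give no pointer to a direction for this change. Compound 3 is therefore expected to stay close to compound 2, with the step of no change at the digits printed from compound 2 to compound 3 (within the scatter) not beyond the scatter. The estimate for compound 3 in this assay is 20000 nM, ranging from 8000 nM to 50000 nM.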

Compound 3, half-maximal inhibitory concentration: 18000 nM
Compound 3: middle estimate off by 1.1-fold (0.05 log units), on the high side; the range from low to high includes it.
By their numbers in this assay, from the lowest: compounds 1, 3 and 2 (each within the scatter of the next).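

In this assay, fluoro in place of chloro on the aromatic carbon para to a large group gives a 1.1-fold lower number from compound 2 to compound 3 (0.05 log units; within the scatter) and so adds a halogen swap to the earlier move of chloro, which was also within the scatter. The listed step to the 4-fluorophenyl group from the 2-chlorophenyl group, a 1.1-fold higher number from compound 1 to compound 3 (0.02 log units; within the scatter), likewise leaves the compounds unordered, so among these three compounds neither change separates the values at this end of the molecule. No available evidence gives a reason for this result.

The compounds shown leave open whether an amine or a carboxylic acid at this aromatic carbon would move the number beyond the scatter. They also leave open whether a longer chain in place of the phenoxymethyl link would do so.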